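A few compounds are considered here, and "the series" means these few. Any claim that something is new, unique, unknown or untested is made for them only; others in the source may bear on it.

Measured so far:
compound 1, `COc1cc(C)cc(-c2c(-c3ccnc(-c4ccc(C(C)=O)cc4)c3)cnn2CC#N)c1`, 15%
compound 2, `COc1cc(C)cc(-c2nn(CC#N)cc2-c2ccc(-c3cccc(C(C)=O)c3)nc2)c1`, 9%
compound 3, `COc1cc(C)cc(-c2nn(CC#N)cc2-c2ccnc(-c3ccc(N(C)C)cc3)c2)c1`, 3%

Of the compounds shown here, three sharing one core have been tested in a functional assay on K562 cells (Homo sapiens) for cytotoxicity, read by sulforhodamine B assay, with a stated time of 48 h, tested at 10 uM; on this read-out higher numbers stand for a weaker effect at the one concentration tested and lower numbers for a stronger effect. Compound 1 gives the highest of the three numbers, 15%. Its nearest neighbour is compound 2, whose 9% lies within the usual scatter of the measurement, so the two cannot be told apart on these data. The furthest is compound 3, whose 3% lies beyond the scatter, so compound 3 shows the stronger effect of the two.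

The next compound, compound 4, `COc1cc(C)cc(-c2c(-c3ccnc(-c4ccc(N(C)C)cc4)c3)cnn2CC#N)c1`, has not yet been measured. It differs from compound 1 in one place: dimethylamino in place of acetyl on an aromatic carbon. Going by the values given here, no pair of measured compounds differs in exactly this way, so no measured step tells what it does. What can be said is that compound 3, which carries a dimethylamino group on a different arrangement of the same core, gives the lowest of the three numbers. On that basis a modest step downward in this assay, of roughly the size of the scatter, is expected from compound 1 to compound 4, that is a number 9 percentage points lower from compound 1 to compound 4 (within the scatter). Compound 4 is therefore estimated at 6%, with a range from 0% to 17%.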

Compound 4, a percentage reported as activity, at one concentration (the size of the read-out at that concentration, not a potency): -5%
The estimate for compound 4 lay 11 percentage points above the measured number; the measured number lies below the stated range.
By their numbers in this assay, from the lowest: compounds 4, 3, 2 and 1 (each within the scatter of the next, the first and the last beyond it).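

In this assay, going by these compounds alone, dimethylamino in place of acetyl on an aromatic carbon, para to a large group, gives a number 20 percentage points lower from compound 1 to compound 4 (beyond the scatter), a step the earlier compounds could not show, as no two of them differ in one place. It shows that, with the rest of compound 1 unchanged, the read-out responds to what this position carries, even though the group that leaves and the group that enters have the same count of heavy atoms and of hydrogen-bond acceptors, so neither count separates them. No measurement at hand bears on the reason for this step.

The compounds shown leave open how other groups at this place, such as a primary amine or a carboxylic acid, would read in this assay, since one exchange of two groups gives no trend. They also leave open whether the same exchange would produce a step of similar size on the other arrangement of the core found in compound 2 and compound 3, which differ from each other in more than one place.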